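This account rests on a few compounds, and the source may have more. Where it says the series, first, only, none or still open, it means among the compounds named here.

Measured so far in an assay on cells (Ventricular myocyte) for inhibition of potassium voltage-gated channel subfamily KQT member 1 (Cavia porcellus), read by patch clamp; a lower number here means a stronger inhibitor, a higher number a weaker inhibitor:
compound 1 `CCOc1ccc2c(c1)/C(=N/N1CC(=O)N(CCCCN3CCCCC3)C1=O)CCO2` gives 1040 nM
compound 2 `O=C1CN(/N=C2\CCOc3ccc(Cl)cc32)C(=O)N1CCCCN1CCCCC1` gives 61000 nM

Among the measured compounds shown here, compound 2 stands at the higher of the two numbers: the single measured step, a 59-fold higher number from compound 1 to compound 2 (1.77 log units; beyond the scatter), separates it from compound 1, which is the only neighbour for comparison.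

Compound 3 `CN1CCN(CCCN2C(=O)CN(/N=C3\CCOc4ccc(Cl)cc43)C2=O)CC1` is not yet measured. It differs from compound 2 at the chain end, (4-methylpiperazin-1-yl in place of (piperidin-1-yl)methyl on a saturated chain carbon, three bonds along the chain from an amide-type nitrogen in a ring). For the measured compounds named here, no measured step touches this part of the shared core; the one known step concerns the aromatic ring and is therefore of no direct use for this change. With nothing to indicate a shift in either direction, the step of a 1.1-fold higher number from compound 2 to compound 3 (0.06 log units; within the scatter) is expected to stay within the scatter. Compound 3 is therefore estimated at 70000 nM in this assay, within the range 25000 nM to 200000 nM, with some chance that so weak a value is reported only as a limit.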

Compound 3, half-maximal inhibitory concentration: 5.8 nM
Beside the measured number, compound 3's estimate is 12000-fold (4.08 log units) above it, outside the stated range (below it).
By their numbers in this assay, from the lowest: compound 3; then compound 1; then compound 2.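

In this assay, among the compounds shown here, the chain end matters far more than the one earlier change suggested: 4-methylpiperazin-1-yl in place of (piperidin-1-yl)methyl gives an 11000-fold lower number from compound 2 to compound 3 (4.02 log units; beyond the scatter) and this exceeds a 59-fold higher number from compound 1 to compound 2 (1.77 log units; beyond the scatter) on the aromatic carbon. Chloro on the aromatic carbon therefore does not hold the series at weak numbers, and since the same difference also reads 3-(piperidin-1-yl)propyl to 2-(4-methylpiperazin-1-yl)ethyl, ring and chain change together in this step. No supporting information bears on the size of this step.

A 3-(piperidin-1-yl)propyl chain end on the chloro compound, or a 4-(4-methylpiperazin-1-yl)butyl one, would separate the chain from the ring. Going by these compounds, whether ethoxy adds to the 4-methylpiperazin-1-yl chain end, and whether a morpholine ring there behaves like either amine, remains open.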